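The compounds below may be only part of what the source reports. "The series", "measured", "known", "first", "only" and "open" are said of these compounds alone.

Of the compounds shown here, two built on a shared core have been measured in an ADME assay on microsomes from liver (Rattus norvegicus) for metabolic stability, tested at 2.5 uM; on this read-out higher numbers stand for fast clearance and lower numbers for slow clearance. Compound 1 `O=S(=O)(c1ccc(F)c(F)c1)c1cnc2c(F)cccc2c1-c1ccc(Cl)cc1` gives 0.2 mL/min in this assay. Compound 2 `O=S(=O)(c1ccc(F)c(Cl)c1)c1cnc2cc(F)ccc2c1-c1ccc(Cl)cc1` gives 0.45 mL/min in this assay, the higher of the two numbers, and its gap to compound 1 is beyond the usual scatter of repeated measurements. Compound 3 `O=S(=O)(c1ccc(F)c(F)c1)c1cnc2cc(F)ccc2c1-c1ccc(Cl)cc1` has not yet been measured. Compared with compound 2 it carries a single change: fluoro in place of chloro on an aromatic carbon. Among the compounds with values here, compound 3 therefore combines the 3,4-difluorophenyl of compound 1 with the core of compound 2, and no measured pair differs in just one place, so no single step can be read directly. A small downward step in this assay is expected, a 1.5-fold lower number from compound 2 to compound 3 (0.18 log units; within the scatter), since compound 1 with the same 3,4-difluorophenyl gives 0.2 mL/min. Compound 3 is thus estimated to give 0.3 mL/min in this assay, within a range of 0.15 mL/min to 0.6 mL/min.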

Compound 3, intrinsic clearance in a liver preparation (reported as CLH), per the amount of preparation that the assay uses: 1.41 mL/min
The estimate for compound 3 lay 4.7-fold (0.67 log units) below the measured number; the whole stated range lies below it.
By their numbers in this assay, from the lowest: compound 1; then compound 2; then compound 3.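

In this assay the change from 3-chloro-4-fluorophenyl to 3,4-difluorophenyl, a single atom exchanged on that ring, gives a 3.1-fold higher number from compound 2 to compound 3 (0.50 log units; beyond the scatter) and so counts as a real step, showing that this position is not indifferent to fluoro in place of chloro. The 3,4-difluorophenyl also does not go with a low number on its own, since compound 1 carries it at 0.2 mL/min and compound 3 carries it at 1.41 mL/min in the same read-out. Nothing available explains why this exchange moves the number upward.

The compounds shown hold only chloro and fluoro at this place, so how a methoxy group or a nitrile would read there stays open. From the compounds shown here alone, whether the same exchange gives a step of similar size on the core of compound 1 is also open.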